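Amide nitrogen substitution in a small acid series

The compounds below may be only part of what the source reports. "The series", "measured", "known", "first", "only" and "open" are said of these compounds alone.

Measured compounds:
compound 1 `CNC(=O)c1nc(-c2ccccc2)[nH]c1C(=O)O` — "not determined" (no result reported)
compound 2 `O=C(O)c1[nH]c(-c2ccccc2)nc1C(=O)N1CCOCC1` — > 200000 nM

In a functional assay on PC-3 cells (Homo sapiens) for inhibition (a lower number here means a stronger inhibitor of growth, a higher number a weaker inhibitor of growth), compound 1 gives "not determined" (no result reported), so no number is available for it. For compound 2 the result is a limit of the assay: > 200000 nM. Among the compounds with values here, compound 1 therefore stands without a measured position, and the only further value in the set is the limit of > 200000 nM in this assay, at which 1 of the 2 values shown sits.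

Compound 3 `CN(CC(N)=O)C(=O)c1nc(-c2ccccc2)[nH]c1C(=O)O` differs from compound 1 by carbamoylmethyl in place of hydrogen on an amide-type nitrogen. Within the data shown here, no step between measured compounds exists, so the size of this change in this assay cannot be read from a measured pair; nothing in the set points to a step beyond the scatter in either direction, and no direction is assumed.

Because compound 2 sits at the limit of > 200000 nM in this assay, at which 1 of the 2 values shown sits, compound 3 is not expected to reach a measurable value. Compound 3 is estimated at 200000 nM, with a range from 50000 nM to 600000 nM, and a limit rather than a number is the expected read-out.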

Compound 3, concentration for 50% growth inhibition: > 200000 nM
Compound 3: a limit, no number (the forecaster's own chance of this, stated with the estimate: 75%); the middle value lies on the limit itself.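

No step from compound 2 to compound 3 can be read in this assay, as both results are limits rather than numbers: the limit of > 200000 nM in this assay, at which 2 of the 3 values shown sit.

The compounds shown leave open whether changing the substituents on the amide nitrogen can shift growth inhibition in this assay at all.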